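From Phenyl to Pyridin-3-yl on Compound 2

The source may report more compounds than this note shows. Statements on the series, on what has been measured and on what is new or still open speak of the compounds shown alone.

For the measured compounds named here, in an ADME assay on LLC-PK1 cells (Sus scrofa) for permeability (on this read-out lower numbers stand for lower permeability and higher numbers for higher permeability), compound 2 `Cn1cc(C(=O)Nc2ccc(-c3ccccc3)c(C(F)(F)F)c2)c(=O)c2ccccc21` gives 1.2 10^-6 cm/s, the lower of the two numbers measured so far. Compound 1 `Cn1cc(C(=O)Nc2cnc(-c3ccccc3)c(C(F)(F)F)c2)c(=O)c2ccccc21` gives 11 10^-6 cm/s, and that gap lies beyond the usual scatter. Compound 3 `Cn1cc(C(=O)Nc2ccc(-c3cccnc3)c(C(F)(F)F)c2)c(=O)c2ccccc21` has pyridin-3-yl in place of phenyl on an aromatic carbon of compound 2, a change counted as pyridin-3-yl in place of phenyl on an aromatic carbon. Going by the values given here, no measured pair shows this exact change, so its size remains a judgement. The expected change is a moderate rise, slightly beyond the scatter, with an estimated 2.5-fold higher number from compound 2 to compound 3 (0.40 log units; beyond the scatter). For compound 3 the estimated value is 3 10^-6 cm/s, with an expected range of 1.2 10^-6 cm/s to 8 10^-6 cm/s.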

Compound 3, apparent permeability: 18 10^-6 cm/s
Beside the measured number, compound 3's estimate is 6.0-fold (0.78 log units) below it; measured number outside the range, above it.
By their numbers in this assay, from the lowest: compound 2; then compounds 1 and 3 (each within the scatter of the next).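

Swapping phenyl for pyridin-3-yl at this position, ortho to a trifluoromethyl group and para to a large group, gives a 15-fold higher number from compound 2 to compound 3 (1.18 log units; beyond the scatter) in this assay and so counts as a large step. The entering ring holds a nitrogen where the leaving ring holds a carbon, and that alone moves this read-out well beyond the scatter. Nothing measured here explains the rise.

Still open, from the compounds shown here alone, is whether the place of the nitrogen in the ring matters, as pyridin-4-yl at this position would show. An amine or a carboxylic acid on the phenyl ring could show whether other groups move the number as far.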